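The source may hold more compounds than are shown below. What is called first, only, known or untested is meant among the compounds shown, and "the series" means these compounds.

Compound 1 `COc1cc(-n2ncnc2-c2ccc(F)cc2)cc(OC)c1OC` and compound 2 `COc1cc(-n2ncnc2-c2cccc(Cl)c2)cc(OC)c1OC` share one core and differ only in the aryl group attached to it. In a functional assay on MCF7 cells (Homo sapiens) for antiproliferative activity, read by MTT assay, with a stated time of 72 h (on this read-out higher numbers stand for weaker inhibition and lower numbers for stronger inhibition), compound 1 gives only a limit of the assay, > 10000 nM. In this assay compound 2 likewise gives only a limit, > 10000 nM. The step that the two limits leave unreadable from compound 1 to compound 2 cannot be read because of the limit of > 10000 nM in this assay, at which 2 of the 2 values shown sit. Compound 3 `CCOc1ccc(-c2ncnn2-c2cc(OC)c(OC)c(OC)c2)cc1Cl` differs from compound 2 by ethoxy in place of hydrogen on an aromatic carbon, placed ortho to a chloro group and para to a large group. Going by the values given here, no measured step bears on this change, and compound 2 stands at the limit, so no direction can be drawn from the data. Compound 3 is estimated at 5000 nM, with a range from 500 nM to 20000 nM. That estimate implies an expected step of an at least 2.0-fold lower number from compound 2 to compound 3 (0.30 log units; that floor lies within the scatter).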

Compound 3, half-maximal inhibitory concentration: 17 nM
Compound 3: middle estimate off by 290-fold (2.47 log units), on the high side; the measured number lies below the stated range.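

Ethoxy in place of hydrogen, ortho to a chloro group and para to a large group, brings an at least 580-fold lower number from compound 2 to compound 3 (2.76 log units; beyond the scatter) in this assay. This carbon, bearing only hydrogen in compound 2, thus matters on this read-out, which compound 1 and compound 2 could not show. The size of the step is only a floor, because compound 2 stands at a limit: the limit of > 10000 nM in this assay, at which 2 of the 3 values shown sit.

The compounds shown leave open whether methoxy, a longer chain such as propoxy, or an amine would serve at this carbon. They also leave open whether ethoxy needs the chloro group.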